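Swapping a Cyclohexylmethyl Ester Tail for a Benzodioxinyl Group

A few compounds are considered here, and "the series" means these few. Any claim that something is new, unique, unknown or untested is made for them only; others in the source may bear on it.

Compound 1 `C/C=C1/[C@H](O[C@@H]2O[C@H](CO)[C@@H](O)[C@H](O)[C@H]2O)OC=C(C(=O)OC)[C@H]1CC(=O)OCCC1CCCCC1`: 2000 nM
Compound 2 `C/C=C1/[C@H](O[C@@H]2O[C@H](COC(C)=O)[C@@H](OC(C)=O)[C@H](OC(C)=O)[C@H]2OC(C)=O)OC=C(C(=O)O)[C@H]1CC(=O)OC`: > 20000 nM

Of the compounds shown here, two have been measured in a functional assay on SK-BR-3 cells (Homo sapiens) for antiproliferative activity, read by MTT assay, with a stated time of 72 h; on this read-out higher numbers stand for weaker inhibition and lower numbers for stronger inhibition. Among the measured compounds shown here, compound 1 gives 2000 nM in this assay, which is the only actual number among the values shown. Compound 2 shows > 20000 nM in this assay, and this is a limit of the assay rather than a measured number (the limit of > 20000 nM in this assay, at which 1 of the 2 values shown sits). For the measured compounds named here, the two measured compounds differ in several places at once, so no single measured step shows how one change alone moves the read-out.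

Compound 3 `C/C=C1/[C@H](O[C@@H]2O[C@H](CO)[C@@H](O)[C@H](O)[C@H]2O)OC=C(C(=O)OC)[C@H]1CC(=O)OCc1ccc2c(c1)OCCO2` differs from compound 1 in one place: 2,3-dihydro-1,4-benzodioxin-6-yl in place of cyclohexylmethyl on a saturated chain carbon bound to an oxygen next to a carbonyl group. Without a comparable measured step to lean on, the step from compound 1 to compound 3 is expected to be small, a 1.3-fold lower number from compound 1 to compound 3 (0.12 log units; within the scatter), and not clearly beyond the usual scatter in either direction. Compound 3 is therefore estimated at 1500 nM in this assay, with a plausible range from 500 nM to 5000 nM.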

Compound 3, half-maximal inhibitory concentration: > 15000 nM
Compound 3: no number, only a limit; the forecaster's own chance of this, stated with the estimate: 10%; middle value at least 10-fold (1.00 log units) away from the limit.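

Exchanging cyclohexylmethyl for 2,3-dihydro-1,4-benzodioxin-6-yl on a saturated chain carbon bound to an oxygen next to a carbonyl group gives an at least 7.5-fold higher number from compound 1 to compound 3 (0.87 log units; beyond the scatter) in this assay. This is the first single change shown, and with the shared core left untouched, it shows that inhibition in this assay is sensitive to the ester tail. Compound 3 reads > 15000 nM, which is a limit of the assay and not a number: the limit of > 15000 nM in this assay, at which 1 of the 3 values shown sits.

The compounds shown do not separate the parts of this change, namely the aromatic ring, the two ring oxygens and the swap of 2-cyclohexylethyl for (2,3-dihydro-1,4-benzodioxin-6-yl)methyl. From the compounds shown here alone, it also remains open how a plain benzyl or 2-phenylethyl tail, or a chain ending in an amine, would compare with compound 1.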